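The source may hold more compounds than are shown below. What is called first, only, known or untested is meant among the compounds shown, and "the series" means these compounds.

Compound 3 `Cc1nc(S(C)(=O)=O)ccc1Oc1ncnc(OC2CCN(C(=O)OC3(C(F)(F)F)COC3)CC2)c1F` sits second highest of the three numbers measured in a functional assay on isolated protein for inhibition of Glucose-dependent insulinotropic receptor (Homo sapiens), read by HTRF and cAMP accumulation; on this read-out lower numbers stand for an effect already at smaller amounts and higher numbers for an effect only at larger amounts of compound: in that assay compound 3 gives 29.3 nM. Its nearest neighbour is compound 2 `Cc1nc(S(C)(=O)=O)ccc1Oc1ncnc(OC2CCN(C(=O)OC3(C(F)(F)F)CCC3)CC2)c1F`, which in this assay gives 14.3 nM, so that a 2.0-fold higher number from compound 2 to compound 3 (0.31 log units; beyond the scatter). Furthest away is compound 1 `Cc1nc(S(C)(=O)=O)ccc1Oc1ncnc(OC2CCN(C(=O)OC3COC3)CC2)c1F`, which in this assay gives 326 nM, with an 11-fold lower number from compound 1 to compound 3 (1.05 log units; beyond the scatter) and a 23-fold lower number from compound 1 to compound 2 (1.36 log units; beyond the scatter).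

Compound 4 `Cc1nc(S(C)(=O)=O)ccc1Oc1ncnc(OC2CCN(C(=S)OC(C)C)CC2)c1F` has not yet been measured in this assay. It differs from compound 3 in one place: a group of 6 heavy atoms (4 carbon, 1 oxygen, 1 sulfur; no ring) in place of a group of 11 heavy atoms (5 carbon, 3 oxygen, 3 fluorine; one four-membered non-aromatic ring with 1 hetero atom), on an amine nitrogen in a ring. The two steps that bear on this change are the ones from compound 1, where a trifluoromethyl-bearing ring group entered in place of oxetan-3-yl and the number fell by a large amount in both cases. In compound 4 that trifluoromethyl and the four-membered ring leave, and a smaller acyclic group with a sulfur enters. Among the measured compounds shown here, no measured step covers a sulfur for a carbonyl oxygen or an acyclic group of this kind, so the direction rests on the two large steps alone; a number closer to that of compound 1 than to that of compound 3 is expected. Compound 4 is therefore estimated at 150 nM in this assay, within a range of 40 nM to 600 nM, which would mean a 5.1-fold higher number from compound 3 to compound 4 (0.71 log units; beyond the scatter).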

Compound 4, half-maximal effective concentration: 69.9 nM
For compound 4 the middle estimate is 2.1-fold (0.33 log units) above the measured one; low and high end bracket the measured number.
By their numbers in this assay, from the lowest: compound 2; then compound 3; then compound 4; then compound 1.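

In this assay, the group on the amine nitrogen in a ring does not need a trifluoromethyl or a four-membered ring to give a lower number than the oxetan-3-yl carbamate: the group of 6 heavy atoms, with sulfur and no ring, brings a 4.7-fold lower number from compound 1 to compound 4 (0.67 log units; beyond the scatter). It does not match the two trifluoromethyl-bearing ring groups, however, with a 2.4-fold higher number from compound 3 to compound 4 (0.38 log units; beyond the scatter) and a 4.9-fold higher number from compound 2 to compound 4 (0.69 log units; beyond the scatter), so this position tolerates quite different groups while still separating them by amounts beyond the scatter. Nothing measured here accounts for any of these steps.

The sulfur and the acyclic chain entered together, so the compounds shown leave open how much of the step belongs to each, a question that the same isopropyl group on a plain carbonyl oxygen would address. They also leave open whether a nitrogen in place of the oxygen of this group, as in a urea, or a longer chain such as tert-butyl or n-butyl would move the number towards that of the ring groups or away from it.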